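The compounds below may be only part of what the source reports. "The series", "measured", "known", "first", "only" and "open" are said of these compounds alone.

Measured compounds:
compound 1 `COc1cc(C2CC(c3ccccc3)=NN2c2ccc(-c3ccccc3)nn2)cc(OC)c1OC` gives 70000 nM in a functional assay on MCF7 cells (Homo sapiens) for antiproliferative activity, read by MTT assay, with a stated time of 24 h; on this read-out lower numbers stand for stronger inhibition and higher numbers for weaker inhibition
compound 2 `COc1ccc(C2=NN(c3ccc(-c4ccccc4)nn3)C(c3ccc(OC)cc3)C2)cc1` gives 100000 nM in this assay

Compound 2 stands at the highest of the two numbers in this assay, and its nearest neighbour is compound 1, whose number lies within the scatter of repeated measurements of compound 2. Both compounds therefore show weak inhibition, and no order between them can be read from these two values.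

Compound 3 `COc1ccc(C2=NN(c3ccc(-c4ccccc4)nn3)C(c3cc(OC)c(OC)c(OC)c3)C2)cc1` has not yet been measured. It differs from compound 2 in one place: 3,4,5-trimethoxyphenyl in place of 4-methoxyphenyl on a saturated ring carbon. Compound 1 also carries a 3,4,5-trimethoxyphenyl on a saturated ring carbon of its core, and its value of 70000 nM in this assay sits close to that of compound 2. With nothing in the two measured compounds pointing to a large shift, the step from compound 2 to compound 3 is expected to be small, in no clear direction, and within the scatter, as a 1.3-fold lower number from compound 2 to compound 3 (0.12 log units; within the scatter) expresses. Compound 3 is accordingly estimated at 75000 nM in this assay, with a range from 30000 nM to 150000 nM.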

Compound 3, half-maximal inhibitory concentration: 100000 nM
For compound 3 the middle estimate is 1.3-fold (0.12 log units) below the measured one; low and high end bracket the measured number.
By their numbers in this assay, from the lowest: compounds 1, 2 and 3 (each within the scatter of the next).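

In this assay, 3,4,5-trimethoxyphenyl in place of 4-methoxyphenyl on the saturated ring carbon next to the ring nitrogen gives no change at the digits printed from compound 2 to compound 3 (within the scatter), so the larger aryl group at this position brings no readable shift, with compound 3 at 100000 nM. Methoxy in place of hydrogen on an aromatic carbon, the one difference between compound 1 and compound 3, gives a 1.4-fold higher number from compound 1 to compound 3 (0.15 log units; within the scatter), so this second change can also not be told apart from the scatter, and the earlier pair of values could not show either of these single-place comparisons. Nothing given here bears on why these values lie so close together.

Open, from the compounds shown here alone, is whether a group of a different kind on the same saturated ring carbon, such as an aryl ring carrying an amine or a carboxylic acid, would move the number at all. Going by these compounds, since all three compounds sit in the same weak range, it also remains open whether these two changes would stay as silent in a compound with a much lower number in this assay.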